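Lengthening the Ethoxy Chain to Pentyloxy

The compounds below may be only part of what the source reports. "The series", "measured", "known", "first", "only" and "open" are said of these compounds alone.

- Compound 1 `O=C1Nc2c(ccc(F)c2F)C1(c1ccccc1)c1ccc(O)cc1` gives 8.9 nM
- Compound 2 `CCOc1ccc(C2(c3ccc(O)cc3)C(=O)Nc3c2ccc(F)c3F)cc1` gives 24 nM

In a functional assay on PC-3 cells (Homo sapiens) for cytotoxicity, read by WST assay, with a stated time of 72 h (a higher number here means a weaker inhibitor, a lower number a stronger inhibitor), compound 2 has the higher of the two numbers, with compound 1 as its nearest neighbour. Compound 3 `CCCCCOc1ccc(C2(c3ccc(O)cc3)C(=O)Nc3c2ccc(F)c3F)cc1` differs from compound 2 by propyl in place of hydrogen on a saturated chain carbon, two bonds along the chain from an oxygen on an aromatic ring in a change from ethoxy to pentyloxy. The measured step of a 2.7-fold higher number from compound 1 to compound 2 (0.43 log units; beyond the scatter) is the only one that bears on this, and it was modest. One step sets no trend, but another modest rise in the number is expected. The estimate is a 1.7-fold higher number from compound 2 to compound 3 (0.22 log units; within the scatter) as the expected step. For compound 3 the expected value is 40 nM (estimated range 14 nM to 110 nM).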

Compound 3, half-maximal inhibitory concentration: > 1000 nM
Compound 3: only a limit was reported (the forecaster's own chance of this, stated with the estimate: 3%); middle value at least 25-fold (1.39 log units) from the limit.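

In this assay, lengthening ethoxy to pentyloxy gives an at least 41-fold higher number from compound 2 to compound 3 (1.61 log units; beyond the scatter), and pentyloxy in place of hydrogen on the aromatic carbon gives an at least 110-fold higher number from compound 1 to compound 3 (2.05 log units; beyond the scatter). The value for compound 3 is a limit of the assay, not a number: the limit of > 1000 nM in this assay, at which 1 of the 3 values shown sits. The modest step to ethoxy had not shown that the length of this chain could matter so much, and the loss here is large.

Going by these compounds, whether a propoxy or butoxy chain behaves more like ethoxy or pentyloxy stays open. So does the effect of an amine or a carboxylic acid in place of the pentyloxy group.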